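The source may report more compounds than this note shows. Statements on the series, on what has been measured and on what is new or still open speak of the compounds shown alone.

Of the compounds shown here, two have been measured in a functional assay on A549 cells (Homo sapiens) for cytotoxicity, read by MTT assay, with a stated time of 72 h; a lower number here means a stronger inhibitor, a higher number a weaker inhibitor. Compound 1 (`COc1ccc(/C=C2\CCC/C(=C\c3cccc(OC)c3OC)C2=O)cc1OC`) gives 14400 nM, and compound 2 (`COc1cc(/C=C2\CCC/C(=C\c3cccc(OC)c3OC)C2=O)cc(OC)c1`) gives 10200 nM. These two values lie within the scatter of each other, so compound 2 stands level with compound 1 and the numbers do not rank them. Among the measured compounds shown here, no pair of measured compounds differs in a single place, so the data offer no direct measure of what one substitution does.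

Compound 3 (`COc1cccc(/C=C2\CCC/C(=C\c3cc(OC)c(OC)c(OC)c3)C2=O)c1OC`) has not yet been measured in this assay. It differs from compound 2 by methoxy in place of hydrogen on an aromatic carbon, ortho to two methoxy groups and para to a large group. The expectation rests on the close agreement of the two measured compounds, with compound 1 at 14400 nM and compound 2 at 10200 nM. No shift beyond the scatter is expected in this assay, and no direction is favoured with confidence. The expected change is a 1.1-fold lower number from compound 2 to compound 3 (0.05 log units; within the scatter). Compound 3 is estimated at 9000 nM, with an expected range of 4000 nM to 20000 nM.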

Compound 3, half-maximal inhibitory concentration: 5900 nM
Compound 3: the middle estimate sits 1.5-fold (0.18 log units) above what was measured, and the stated range covers the measured number.
By their numbers in this assay, from the lowest: compounds 3, 2 and 1 (each within the scatter of the next, the first and the last beyond it).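

The result gives the series its first direct measure of methoxy in place of hydrogen on an aromatic carbon, here ortho to two methoxy groups and para to a large group. In this assay, this change gives two readings that differ in how they stand against the scatter: one is within it (a 1.7-fold lower number from compound 2 to compound 3 (0.24 log units; within the scatter)), so compound 2 and compound 3 remain level, while the other passes beyond it, though only modestly (a 2.4-fold lower number from compound 1 to compound 3 (0.39 log units; beyond the scatter)), so compound 3 is separated from compound 1 alone. No measurement is available to explain these steps.

The compounds shown leave open whether a hydroxyl group, an amine or a longer chain such as ethoxy at this same aromatic carbon would give a step clearly beyond the scatter from compound 2, or whether the number at this place responds little to what is put there. They also leave open whether the same methoxy in place of hydrogen would give a similar step on a core carrying a different set of methoxy groups on its other aromatic ring.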